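This account rests on a few compounds, and the source may have more. Where it says the series, first, only, none or still open, it means among the compounds named here.

Among the compounds with values here, in a physicochemical assay for solubility, read by nephelometry, at pH 7.4 (a higher number here means a more soluble compound, a lower number a less soluble compound), compound 2 (`COc1cccc(NC(=O)c2nnn(Cc3ccc(OC(F)(F)F)cc3)c2N)c1`) gives 12000 nM as the lower of the two numbers so far, while compound 1 (`COc1cccc(NC(=O)c2nnn(Cc3ccc(C#N)cc3)c2N)c1`) gives 216000 nM as the higher. Compound 3 (`COc1cccc(NC(=O)c2nnn(Cc3ccc(-n4cccn4)cc3)c2N)c1`) has 1H-pyrazol-1-yl in place of trifluoromethoxy on an aromatic carbon. Within the data shown here, only one measured step bears on this change, namely an 18-fold lower number from compound 1 to compound 2 (1.26 log units; beyond the scatter) on that same aromatic carbon, and it is large and beyond the scatter. Among the measured compounds shown here, no measured compound carries 1H-pyrazol-1-yl, so that step guides the direction only: trifluoromethoxy leaves here, whereas it entered there. The expected step is a 2.9-fold higher number from compound 2 to compound 3 (0.46 log units; beyond the scatter) in the same read-out, a moderate rise that stays smaller than the measured one. The estimated value for compound 3 is 35000 nM (expected range 10000 nM to 120000 nM).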

Compound 3, solubility: 20000 nM
Compound 3: the middle estimate sits 1.8-fold (0.24 log units) above what was measured; the range from low to high includes it.
By their numbers in this assay, from the lowest: compounds 2 and 3 (each within the scatter of the next); then compound 1.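

In this assay, 1H-pyrazol-1-yl in place of trifluoromethoxy on this aromatic carbon gives a 1.7-fold higher number from compound 2 to compound 3 (0.22 log units; within the scatter), so the read-out does not separate these two groups, although one brings a five-membered aromatic ring and the other no ring. With 1H-pyrazol-1-yl in place of cyano, the same carbon gives an 11-fold lower number from compound 1 to compound 3 (1.03 log units; beyond the scatter), which leaves compound 1 alone at the top of the three, with two different replacements of its cyano group both ending far lower. Nothing available explains why the cyano compound stands apart. From the compounds shown here alone, whether an amine or a carboxylic acid on this carbon would read like cyano or like the other two groups stays open. So does whether these steps would hold with a group other than methoxy elsewhere on the shared core.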